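The source may hold more compounds than are shown below. What is called first, only, known or untested is meant among the compounds shown, and "the series" means these compounds.

In an ADME assay on Vero cells (Chlorocebus sabaeus) for cytotoxicity, read by crystal violet staining (on this read-out lower numbers stand for higher toxicity in this test and higher numbers for lower toxicity in this test), compound 2 (`Fc1ccc(F)c(/N=N/Nc2cccc(C(F)(F)F)c2)c1`) gives 80000 nM, level with compound 3 (`O=[N+]([O-])c1cccc(/N=N/N2CCCC2)c1`) at 80000 nM. Compound 1 (`CN(C)CCCN(/N=N/c1ccc([N+](=O)[O-])cc1)c1ccccc1`) gives 40000 nM, and all three values lie within the scatter of one another. Compound 4 (`CN(C)CCCN(/N=N/c1cc(F)ccc1F)c1cccc(C(F)(F)F)c1`) differs from compound 2 by one change: 3-(dimethylamino)propyl in place of hydrogen on a nitrogen on an aromatic ring, with 3-(dimethylamino)propyl in place of hydrogen on a nitrogen on an aromatic ring. For the measured compounds named here, no measured pair isolates this change. Going by the values given here, compound 1 is the only measured compound bearing this chain, and its 40000 nM is the sole guide, so a small step towards a lower number in this assay is expected, perhaps none beyond the scatter. The estimated step is a 2.0-fold lower number from compound 2 to compound 4 (0.30 log units; within the scatter). Compound 4 is estimated at 40000 nM, with an expected range of 13000 nM to 100000 nM.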

Compound 4, half-maximal cytotoxic concentration: 30000 nM
Compound 4: middle estimate off by 1.3-fold (0.12 log units), on the high side; the range from low to high includes it.
By their numbers in this assay, from the lowest: compounds 4, 1, 2 and 3 (each within the scatter of the next, the first and the last beyond it).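

In this assay, for the compounds shown here, 3-(dimethylamino)propyl in place of hydrogen on a nitrogen on an aromatic ring gives a 2.7-fold lower number from compound 2 to compound 4 (0.43 log units; beyond the scatter) as the first readable step at this position, and it lies beyond the scatter. The step is modest and rests on one pair, so it holds only for this change on the core of compound 2. Nothing available here accounts for the step. On these data alone, whether the terminal dimethylamino group is needed for this step remains open, as a plain propyl chain would test. As far as these compounds go, a longer chain or a morpholine on the same nitrogen also remains open.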